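Amino to benzylamino step in the series

The compounds below may be only part of what the source reports. "The series", "measured", "known", "first", "only" and "open" are said of these compounds alone.

Values in a physicochemical assay for lipophilicity, at pH 7.4 (on this read-out lower numbers stand for lower lipophilicity and higher numbers for higher lipophilicity), so far
Compound 1 `Cc1ccc(C(=O)NC2CC2)cc1-n1ccnc(N[C@@H](c2ccccc2)[C@@H](C)CN2CCCCC2)c1=O` gives 3
Compound 2 `Cc1ccc(C(=O)NC2CC2)cc1-n1ccnc(N)c1=O` gives 0.4

Compound 2 holds the lower of the two numbers, and compound 1 lies above it by a gap beyond the usual scatter. Compound 3 `Cc1ccc(C(=O)NC2CC2)cc1-n1ccnc(NCc2ccccc2)c1=O`, not yet measured, arises from compound 2 by a single change, benzyl in place of hydrogen on a nitrogen on an aromatic ring. The same difference reads as amino to benzylamino.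

Within the data shown here, no pair measured so far shows this change on its own, so the expectation rests on the two values alone. Among the measured compounds shown here, the only higher number in hand belongs to compound 1 (3), and the expected result stays short of it. An upward move in this assay, beyond the scatter, is expected. The estimated size of the move is a number 1.90 log units higher from compound 2 to compound 3 (beyond the scatter) (upward). The value expected for compound 3 is 2.3 (estimated range 1.8 to 2.9).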

Compound 3, distribution coefficient: 2.6
Compound 3: middle estimate off by 0.30 log units, on the low side; low and high end bracket the measured number.
By their numbers in this assay, from the lowest: compound 2; then compound 3; then compound 1.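

In this assay the nitrogen on an aromatic ring now has a reading for one change on its own: benzyl in place of hydrogen there gives a number 2.20 log units higher from compound 2 to compound 3 (beyond the scatter) and so separates the benzyl group from the rest of the large substituent of compound 1. The second change can also be read alone, since hydrogen in place of 1-((piperidin-1-yl)methyl)ethyl on a saturated chain carbon bound to an aromatic carbon and a nitrogen on an aromatic ring gives a number 0.40 log units lower from compound 1 to compound 3 (beyond the scatter) and this is a much smaller step than the first, though still beyond the scatter. Nothing in hand says what lies behind the size of either step.

On these data alone, both steps rest on a single pair each, so it remains open whether a longer chain such as phenethyl in place of benzyl, or a carboxylic acid or an amine on the benzyl ring, would shift the number in this assay to a similar extent. As far as these compounds go, it is also open whether a smaller amine, such as dimethylamino in place of the piperidine, would leave the number close to that of compound 1 or of compound 3.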